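The source may report more compounds than this note shows. Statements on the series, on what has been measured and on what is new or still open speak of the compounds shown alone.

Of the compounds shown here, three sharing one core have been tested in an assay on isolated protein for inhibition of protein deacetylase HDAC6 (Homo sapiens), read by fluorescence, with stated times of 5 min and 60 min; on this read-out higher numbers stand for weaker inhibition and lower numbers for stronger inhibition. Compound 1 `O=C(CCC1C(=O)N(c2ccc(Cl)cc2)C(=O)N1Cc1ccc(Br)cc1)Nc1ccc(C(=O)NO)cc1` gives 9.7 nM. Compound 2 `O=C(CCC1C(=O)N(c2ccc(Cl)cc2)C(=O)N1Cc1ccc(Br)cc1)NCc1ccc(C(=O)NO)cc1` gives 16.5 nM, and the step of a 1.7-fold higher number from compound 1 to compound 2 (0.23 log units; within the scatter) shows that this exchange of groups changes little here. Compound 3 `Cc1ccc(CN2C(=O)N(c3ccc(Cl)cc3)C(=O)C2CCC(=O)Nc2ccc(C(=O)NO)cc2)cc1` gives 4.4 nM, the lowest of the three numbers; the step of a 2.2-fold lower number from compound 1 to compound 3 (0.34 log units; beyond the scatter) is modest but real, and its gap to compound 2 is wider still.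

Compound 4 `Cc1ccc(CN2C(=O)N(c3ccc(Cl)cc3)C(=O)C2CCC(=O)Nc2cccc(C(=O)NO)c2)cc1` is the next step from compound 3. The change is 3-(hydroxycarbamoyl)phenyl in place of 4-(hydroxycarbamoyl)phenyl on an amide-type nitrogen: the hydroxycarbamoyl group moves to another carbon of the same ring, so the two compounds hold the same atoms joined differently. Neither of the measured steps bears on this kind of change; they concern the cap and the linker to the hydroxamic acid, not the position of that acid on its ring. With no guidance from the measured pairs, the expectation for compound 4 in this assay rests on the fact that the whole of the hydroxamic acid arm is rearranged, and a weaker result than for compound 3 is expected, by an estimated step of a 9.1-fold higher number from compound 3 to compound 4 (0.96 log units; beyond the scatter). Compound 4 is therefore expected to give about 40 nM, within a wide range from 8 nM to 200 nM.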

Compound 4, half-maximal inhibitory concentration: > 40 nM
Compound 4: only a limit was reported (the forecaster's own chance of this, stated with the estimate: 5%); the middle value sits exactly at the limit.
By their numbers in this assay, from the lowest: compound 3; then compounds 1 and 2 (each within the scatter of the next). At a limit, above all of these: compound 4.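

In this assay compound 4 gives > 40 nM, which is only a limit and not a number. Even so, the shift of the hydroxycarbamoyl group on its ring is the largest single change seen so far: an at least 9.0-fold higher number from compound 3 to compound 4 (0.95 log units; beyond the scatter), against a 2.2-fold lower number from compound 1 to compound 3 (0.34 log units; beyond the scatter) and a 1.7-fold higher number from compound 1 to compound 2 (0.23 log units; within the scatter). The earlier compounds shown here showed how the number moves when the bromo group or the arm carrying the hydroxamic acid is changed, whereas this pair shows that, with the same atoms and the same counts of donors and acceptors, 3-(hydroxycarbamoyl)phenyl on the amide-type nitrogen gives a clearly weaker result than 4-(hydroxycarbamoyl)phenyl.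

The limit leaves open how much weaker compound 4 really is, and whether the same shift would have a similar effect with bromo in place of methyl, as in compound 1. Also open, going by these compounds, is how this assay would read with a carboxylic acid in place of the hydroxycarbamoyl group, or with a longer chain joining the amide to the shared core.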